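The source may hold more compounds than are shown below. What is called first, only, known or untested is meant among the compounds shown, and "the series" means these compounds.

Measured compounds:
compound 1 `CC(C)c1ccc(NC(=O)N2CCN(c3ncccc3[N+](=O)[O-])CC2)cc1` — 190 nM
compound 2 `CC(C)c1ccc(NC(=O)N2CCN(c3ncccc3Br)CC2)cc1` — 4.6 nM

Going by the values given here, in a functional assay on HEK293 cells for antagonist activity at transient receptor potential cation channel subfamily V member 1 (Rattus norvegicus) (on this read-out lower numbers stand for stronger inhibition and higher numbers for weaker inhibition), compound 2 stands lowest of the two numbers; the single measured step, a 41-fold lower number from compound 1 to compound 2 (1.62 log units; beyond the scatter), is large. Compound 3 `CCc1cccnc1N1CCN(C(=O)Nc2ccc(C(C)C)cc2)CC1` differs from compound 2 by ethyl in place of bromo on an aromatic carbon. Among the compounds with values here, no measured step covers an ethyl at this place; the one step shows only that this position responds strongly to a change of substituent. With nothing more to go on, compound 3 is expected to stay close to compound 2, a step of a 1.5-fold higher number from compound 2 to compound 3 (0.18 log units; within the scatter), within or just beyond the scatter. The estimate for compound 3 in this assay is 7 nM, range 2 nM to 25 nM.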

Compound 3, half-maximal inhibitory concentration: 230 nM
For compound 3 the middle estimate is 33-fold (1.52 log units) below the measured one; measured number above the stated range.
By their numbers in this assay, from the lowest: compound 2; then compounds 1 and 3 (each within the scatter of the next).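

In this assay bromo proves hard to replace at this place: ethyl in its stead gives a 50-fold higher number from compound 2 to compound 3 (1.70 log units; beyond the scatter) and gives up all that bromo gained over nitro. Ethyl and nitro do not separate, with a 1.2-fold higher number from compound 1 to compound 3 (0.08 log units; within the scatter) inside the scatter, so among these three groups only bromo stands apart. No measured evidence accounts for this result.

Going by these compounds, whether chloro or methyl at this place would stay with bromo or fall with ethyl and nitro remains open. On these data alone, an amine or a methoxy group there is equally open.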